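The source may report more compounds than this note shows. Statements on the series, on what has been measured and on what is new or still open speak of the compounds shown alone.

In a functional assay on V79-379A cells (Cricetulus griseus) for cytotoxicity, read by MTT assay, in the presence of a further agent that is not named here (on this read-out higher numbers stand for weaker inhibition and lower numbers for stronger inhibition), compound 1 `COC1=CC(=O)c2c(c(COC(=O)c3ccccc3F)cn2C)C1=O` gives 40 nM, the lower of the two numbers measured, while compound 2 `COC1=CC(=O)c2c(c(COC(=O)c3ccccc3F)c(C)n2C)C1=O` gives 2000 nM. Compound 3 `COC1=CC(=O)c2c(c(COC(N)=O)cn2C)C1=O` keeps the core of compound 1 but differs from it by amino in place of 2-fluorophenyl on a carbonyl carbon. Among the measured compounds shown here, the only measured step, a 50-fold higher number from compound 1 to compound 2 (1.70 log units; beyond the scatter), is a different change, methyl in place of hydrogen on an aromatic carbon. For the measured compounds named here, it says nothing directly about this replacement and shows only that one small change can move the number widely. No measurement tests the carbonyl carbon, so the direction is tentative. In this assay, the expected step is a 5.0-fold higher number from compound 1 to compound 3 (0.70 log units; beyond the scatter), toward a higher number. Compound 3 is estimated at 200 nM, with an expected range of 40 nM to 1000 nM.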

Compound 3, half-maximal inhibitory concentration: 40 nM
Compound 3: middle estimate off by 5.0-fold (0.70 log units), on the high side, and the stated range covers the measured number.
By their numbers in this assay, from the lowest: compounds 1 and 3 (each within the scatter of the next); then compound 2.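

In this assay, amino in place of 2-fluorophenyl on the carbonyl carbon gives no change at the digits printed from compound 1 to compound 3 (within the scatter). The earlier step concerned only methyl on an aromatic carbon; this one shows that, at the carbonyl carbon, the number holds without the six-membered aromatic ring and its fluorine. Nothing measured here explains this result. As far as these compounds go, whether methylamino, dimethylamino or plain phenyl on the carbonyl carbon would hold the number as well remains open. So does whether methyl on the aromatic carbon would move the number as widely with amino on the carbonyl carbon.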